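A few compounds are considered here, and "the series" means these few. Any claim that something is new, unique, unknown or untested is made for them only; others in the source may bear on it.

Measured in a functional assay on A549 cells (Homo sapiens) for inhibition, read by MTT assay, with a stated time of 72 h; a lower number here means a stronger inhibitor, a higher number a weaker inhibitor:
Compound 1 `Cc1ccccc1NC(=O)CCC(=O)OCCCCCCSc1ccc([N+](=O)[O-])c2nonc12`: 4200 nM
Compound 2 `CN(C)CCCNC(=O)CCC(=O)OCCCCCCSc1ccc([N+](=O)[O-])c2nonc12`: 1580 nM

Compound 2 (1580 nM) holds the lower of the two numbers. Compound 3 (`O=C(CCC(=O)N1CCOCC1)OCCCCCCSc1ccc([N+](=O)[O-])c2nonc12`) has morpholin-4-yl in place of (3-(dimethylamino)propyl)amino on a carbonyl carbon. For the measured compounds named here, no measured compound carries morpholin-4-yl, so the data give no direct reading of that group. Going by the values given here, one measured step bears on the change, with 3-(dimethylamino)propyl in place of 2-methylphenyl on an amide-type nitrogen (a 2.7-fold lower number from compound 1 to compound 2 (0.42 log units; beyond the scatter)), and it is modest. That group now leaves, so a step of similar modest size toward a higher number is expected for compound 3 in this assay on this single precedent. The expected move is a 1.8-fold higher number from compound 2 to compound 3 (0.25 log units; within the scatter) and it remains an estimate. The estimated value for compound 3 is 2800 nM with an expected range of 1000 nM to 7500 nM for this measurement.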

Compound 3, half-maximal inhibitory concentration: 1670 nM
Compound 3: middle estimate off by 1.7-fold (0.22 log units), on the high side; the range from low to high includes it.
By their numbers in this assay, from the lowest: compounds 2 and 3 (each within the scatter of the next); then compound 1.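

In this assay, morpholin-4-yl in place of (3-(dimethylamino)propyl)amino on a carbonyl carbon leaves the reading level (a 1.1-fold higher number from compound 2 to compound 3 (0.02 log units; within the scatter)), so the open chain and the amide hydrogen are not needed at this place to keep the number of compound 2. Morpholin-4-yl in place of (2-methylphenyl)amino gives a 2.5-fold lower number from compound 1 to compound 3 (0.40 log units; beyond the scatter), which means two quite different groups, one with a ring and one without, both stand apart from compound 1 by a modest step. No supporting data bear on why these groups read as they do.

A piperazine, a piperidine or a free carboxylic acid on the same carbonyl carbon could show how far this level reading extends. Plain phenylamino would show whether the number of compound 1 belongs to the aromatic ring or to its methyl group.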